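Replacing a phenolic hydroxy with chloro on a quinolinone chalcone

The source may report more compounds than this note shows. Statements on the series, on what has been measured and on what is new or still open speak of the compounds shown alone.

Of the compounds shown here, two sharing the same core have been measured in a functional assay on RXF 393 cells (Homo sapiens) for cytotoxicity, read by sulforhodamine B assay, with a stated time of 24 h; on this read-out lower numbers stand for stronger inhibition of growth and higher numbers for weaker inhibition of growth. Compound 1, `COc1ccc(C(=O)/C=C/c2cc3ccccc3[nH]c2=O)cc1`, carries a methoxy group and gives 8530 nM. Compound 2, `O=C(/C=C/c1cc2ccccc2[nH]c1=O)c1ccc(O)cc1`, carries a hydroxy group in the same place and gives 3230 nM. For the measured compounds named here, the one measured step, a 2.6-fold lower number from compound 1 to compound 2 (0.42 log units; beyond the scatter), is therefore the only guide available, and compound 2 stands at the lower of the two numbers.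

Compound 3, `O=C(/C=C/c1cc2ccccc2[nH]c1=O)c1ccc(Cl)cc1`, differs from compound 2 by chloro in place of hydroxy on an aromatic carbon. Going by the values given here, no measured step shows what a chloro group does here; the only comparison available concerns the oxygen substituents, and it indicates that changing this position can move the number beyond the scatter. A neutral halogen is closer in character to the methoxy of compound 1 than to the hydroxy of compound 2, so compound 3 is expected to land somewhere between the two measured values, with a step of a 1.9-fold higher number from compound 2 to compound 3 (0.27 log units; within the scatter) towards weaker growth inhibition. For compound 3 the estimate in this assay is 6000 nM, with a range from 2500 nM to 15000 nM.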

Compound 3, concentration for total growth inhibition: 29900 nM
For compound 3 the middle estimate is 5.0-fold (0.70 log units) below the measured one; the whole stated range lies below it.
By their numbers in this assay, from the lowest: compound 2; then compound 1; then compound 3.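

In this assay, swapping the group para to a large group on this aromatic ring can change the number far more than the swap between the two oxygen groups suggested: a 9.3-fold higher number from compound 2 to compound 3 (0.97 log units; beyond the scatter) is a larger step than a 2.6-fold lower number from compound 1 to compound 2 (0.42 log units; beyond the scatter) on the same ring carbon. Chloro also does not behave like a stand-in for methoxy, since a 3.5-fold higher number from compound 1 to compound 3 (0.54 log units; beyond the scatter) shows that it too gives weaker growth inhibition, so among these three groups, both oxygen-linked groups give lower numbers than chloro. Nothing available gives a measured reason for this order.

Going by these compounds, with three groups at one place, it remains open whether the lower numbers follow the oxygen atom attached to the ring, the hydrogen carried by the hydroxy group, or something else about these substituents. On these data alone, an amino group, a fluoro group or a carboxylic acid at the same ring carbon would help separate these readings, and the effect of the same changes elsewhere on the shared core also remains unknown.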